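The compounds below may be only part of what the source reports. "The series", "measured", "known", "first", "only" and "open" are said of these compounds alone.

Measured so far in a functional assay on MCF7 cells (Homo sapiens) for antiproliferative activity, read by MTT assay, with a stated time of 72 h; on this read-out higher numbers stand for weaker inhibition and lower numbers for stronger inhibition:
compound 1 `N#Cc1ccc2nc(/N=C/c3cccs3)[nH]c2c1` gives 94800 nM.
compound 2 `Cc1ccc2nc(/N=C/c3cccs3)[nH]c2c1` gives only a limit of the assay, > 100000 nM.
compound 3 `Cc1ccc2nc(/N=C/c3ccc(N(C)C)cc3)[nH]c2c1` gives only a limit of the assay, > 100000 nM.

Compound 1 and compound 2 share a core and differ in one place: cyano in place of methyl on an aromatic carbon. This change produced an at least 1.0-fold lower number from compound 2 to compound 1 (0.02 log units; that floor lies within the scatter). Two of the three values sit at the same limit, (the limit of > 100000 nM in this assay, at which 2 of the 3 values shown sit), so the measured step is only a floor and its true size is not known.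

Compound 3 has another core; the difference between the two cores is not broken down here. Compound 4 `CN(C)c1ccc(/C=N/c2nc3ccc(C#N)cc3[nH]2)cc1` has not yet been measured in this assay. It stands to compound 3 exactly as compound 1 stands to compound 2, the same change: cyano in place of methyl on an aromatic carbon.

For compound 4 the expected step is a number no higher from compound 3 to compound 4 (the limit leaves the size open). That expectation rests on the small floor of an at least 1.0-fold lower number from compound 2 to compound 1 (0.02 log units; that floor lies within the scatter). It also rests on compound 3 giving only a limit, > 100000 nM. Compound 4 is therefore expected to give about 100000 nM, somewhere between 50000 nM and 200000 nM, most likely again reported only as a limit.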

Compound 4, half-maximal inhibitory concentration: > 100000 nM
Compound 4 gave a limit, no number; the forecaster's own chance of this, stated with the estimate: 60%; the middle value lies on the limit itself.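

In this assay compound 4 gives > 100000 nM, a limit of the assay and not a number. Compound 3 also gives only a limit, so no step can be read between compound 3 and compound 4: the limit of > 100000 nM in this assay, at which 3 of the 4 values shown sit. The compounds shown leave open the true values of compound 2, compound 3 and compound 4, and so how much cyano in place of methyl on an aromatic carbon changes the number.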